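The compounds below may be only part of what the source reports. "The series", "measured", "known", "first", "only" and "open" are said of these compounds alone.

Compound 1 `O=C1NCCN(c2cccc(Cl)c2)N1` is a small heterocyclic compound carrying a chloro group on its attached phenyl ring. In an assay on RBL-1 cells for inhibition of Polyunsaturated fatty acid 5-lipoxygenase (Rattus norvegicus) (on this read-out higher numbers stand for weaker inhibition and lower numbers for stronger inhibition), compound 1 gives 5300 nM, the higher of the two numbers recorded so far. Its nearest neighbour is compound 2 `CC1CN(c2cccc(Cl)c2)NC(=O)N1`, which in this assay gives 2700 nM; the step of a 2.0-fold lower number from compound 1 to compound 2 (0.29 log units; within the scatter) is within the scatter, so the two compounds cannot be told apart on these numbers. Compound 3 `O=C1NCCN(c2cccc(-c3ccccn3)c2)N1` has not yet been measured. It differs from compound 1 by pyridin-2-yl in place of chloro on an aromatic carbon. Within the data shown here, no measured step touches the chloro group: the only step recorded, from compound 1 to compound 2, concerns a methyl on a saturated ring carbon and says nothing about exchanging the chloro for a pyridin-2-yl. The expectation for compound 3 therefore rests on compound 1 alone, with wide uncertainty, and the estimated step is a 1.5-fold lower number from compound 1 to compound 3 (0.18 log units; within the scatter). Compound 3 is expected to give about 3500 nM in this assay, within a range from 700 nM to 18000 nM.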

Compound 3, half-maximal inhibitory concentration: 30000 nM
Estimate against measurement, compound 3: 8.6-fold (0.93 log units) below; measured number above the stated range.
By their numbers in this assay, from the lowest: compounds 2 and 1 (each within the scatter of the next); then compound 3.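

This is the first change shown at the aromatic carbon that holds the chloro group, and it has a clear effect in this assay: pyridin-2-yl in place of chloro gives a 5.7-fold higher number from compound 1 to compound 3 (0.75 log units; beyond the scatter), which means weaker inhibition. Unlike the methyl change on the saturated ring carbon, this step lies beyond the scatter, so the group on this aromatic carbon can affect the read-out even though the rest of the structure stays the same. Nothing available here explains the weakening.

A single replacement cannot separate the effect of losing chloro from that of adding pyridin-2-yl. As far as these compounds go, it also remains open whether fluoro, methoxy or an amine on this carbon would stay close to compound 1, and whether a plain phenyl group would match pyridin-2-yl.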